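The compounds below may be only part of what the source reports. "The series", "measured", "known", "first", "only" and "open" are said of these compounds alone.

Of the compounds shown here, three sharing one core have been measured so far in a functional assay on Ehrlich cells (Mus musculus) for cytotoxicity, tested at 50 ug/mL; a higher number here means a stronger effect of the compound at the concentration tested, a lower number a weaker effect. Compound 3, with the structure `COc1cc(N2C(N)=C(C#N)C(c3ccc(Cl)cc3Cl)C3=C2CC(C)(C)CC3=O)cc(OC)c1OC`, gives 95% and stands highest of the three numbers. Compound 1, with the structure `COc1cc(N2C(N)=C(C#N)C(/C=C/c3ccccc3)C3=C2CC(C)(C)CC3=O)cc(OC)c1OC`, gives 30%, and compound 2, with the structure `COc1cc(N2C(N)=C(C#N)C(c3ccccc3O)C3=C2CC(C)(C)CC3=O)cc(OC)c1OC`, gives 2%. The gaps are clear: a number 65 percentage points higher from compound 1 to compound 3 (beyond the scatter), a number 93 percentage points higher from compound 2 to compound 3 (beyond the scatter), while the smaller shift is a number 28 percentage points lower from compound 1 to compound 2 (beyond the scatter).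

Compound 4, with the structure `COc1cc(N2C(N)=C(C#N)C(c3ccc(C)o3)C3=C2CC(C)(C)CC3=O)cc(OC)c1OC`, is the next one to be tested. It differs from compound 3 in one place: 5-methylfuran-2-yl in place of 2,4-dichlorophenyl on a saturated ring carbon.

For the measured compounds named here, the steps that bear on this change are the two that altered the same saturated ring carbon, namely a number 65 percentage points higher from compound 1 to compound 3 (beyond the scatter) and a number 93 percentage points higher from compound 2 to compound 3 (beyond the scatter). Both are large, and both ended at the 2,4-dichlorophenyl group that compound 4 now gives up. The 5-methylfuran-2-yl group itself has not been tried in this series, so nothing shows where exactly compound 4 will land. Since every group so far other than 2,4-dichlorophenyl produced a much lower number, a sizeable drop is expected for compound 4, roughly a number 55 percentage points lower from compound 3 to compound 4 (beyond the scatter), with wide uncertainty. Compound 4 is therefore estimated to give 40% in this assay, expected to fall between 10% and 75%.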

Compound 4, a percentage reported as activity, at one concentration (the size of the read-out at that concentration, not a potency): 41%
Compound 4: middle estimate off by 1 percentage points, on the low side; the range from low to high includes it.
By their numbers in this assay, from the lowest: compound 2; then compound 1; then compound 4; then compound 3.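

At this saturated ring carbon, this assay shows that a five-membered aromatic ring with 1 hetero atom gives a middling result: putting 5-methylfuran-2-yl in place of 2,4-dichlorophenyl brings a number 54 percentage points lower from compound 3 to compound 4 (beyond the scatter), while putting it in place of 2-hydroxyphenyl brings a number 39 percentage points higher from compound 2 to compound 4 (beyond the scatter). It also edges past the 2-phenylethenyl group, with a number 11 percentage points higher from compound 1 to compound 4 (beyond the scatter), a modest step but one that still lies beyond the usual scatter. Across these four groups, a substituent without chlorine can therefore keep part of the effect, although 2,4-dichlorophenyl alone remains at the top and this one carbon spans nearly the whole range of the read-out.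

No measured information is available to explain why these groups differ. The compounds shown leave open whether the high number of compound 3 depends on its two chlorine atoms or on the six-membered aromatic ring that carries them, which a plain phenyl, a 4-chlorophenyl or an unsubstituted furan-2-yl group at this carbon could help to separate.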